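A few compounds are considered here, and "the series" means these few. Any claim that something is new, unique, unknown or untested is made for them only; others in the source may bear on it.

Compound 1 `c1cncc(-c2nnc(-c3c[nH]c4ccccc34)o2)c1` is one of three compounds tested in a functional assay on MDA-MB-231 cells (Homo sapiens) for cytotoxicity, read by MTT assay; on this read-out lower numbers stand for stronger inhibition and higher numbers for weaker inhibition. In this assay compound 1 gives only a limit, > 1000000 nM. Compound 2 `COc1ccc(-c2nnc(-c3c[nH]c4ccccc34)o2)c(OC)c1OC` likewise gives only a limit in this assay, > 1000000 nM. Compound 3 `COc1cc(-c2nnc(-c3c[nH]c4ccccc34)o2)ccc1O` also gives only a limit in this assay, > 1000000 nM. Compound 1 thus stands where every measured compound stands: the limit of > 1000000 nM in this assay, at which 3 of the 3 values shown sit. Whether any of the three differs from the others cannot be read from numbers that are limits.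

Compound 4 `FC(F)(F)c1nnc(-c2c[nH]c3ccccc23)o1` has not been measured in this assay. It differs from compound 1 in one place: trifluoromethyl in place of pyridin-3-yl on an aromatic carbon. Among the compounds with values here, no step between measured compounds is available to guide the size of this change; all three measured compounds sit at the limit, and their numbers do not distinguish one substituent from another. Compound 4 is expected to remain at or near the limit, and the step from compound 1 to compound 4 in this assay is expected to be a number no higher from compound 1 to compound 4 (the limit leaves the size open), nothing beyond the scatter. Compound 4 is estimated at 1000000 nM, within 300000 nM to 3000000 nM, with a strong chance that only a limit is reported again.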

Compound 4, half-maximal inhibitory concentration: > 1000000 nM
Compound 4: no number, only a limit; the forecaster's own chance of this, stated with the estimate: 80%; the middle value lies on the limit itself.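

Compound 1 and compound 4 both give only limits in this assay, so no step between them can be read: the limit of > 1000000 nM in this assay, at which 4 of the 4 values shown sit.

The compounds shown leave open whether any group on the shared core would give a measurable value in this assay, and how the four compare with one another.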